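The compounds below may be only part of what the source reports. "The series", "measured", "known", "first", "only" and "open" are said of these compounds alone.

Measured so far:
- compound 1 `O=C(NCc1ccccc1)c1cnc(N2CCN(C(=O)c3c(F)cccc3F)CC2)nc1NC1CC1`: 27 nM in a functional assay on HEK293 cells for agonist activity at transient receptor potential cation channel subfamily A member 1 (Homo sapiens), read by fluorescence and calcium flux, with stated times of 1 s and 60 s; a lower number here means that less compound is needed, a higher number that more compound is needed for the effect
- compound 2 `O=C(NCc1ccccc1)c1cnc(N2CCN(Cc3ccccc3)CC2)nc1NC1CC1`: "not active" (no number reported) in this assay

Compound 1 and compound 2 share the same core and differ only in the group carried on the ring nitrogen. In this assay compound 1 gives 27 nM, whereas compound 2 gives "not active" (no number reported), so no single number marks where compound 2 stands; it sits outside the measurable range of this assay, and no size can be put on the gap between the two.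

Compound 3 `O=C(NCc1ccccc1)c1cnc(N2CCN(CC3CCCOC3)CC2)nc1NC1CC1` is the next step from compound 2. The change is oxan-3-yl in place of phenyl on a saturated chain carbon bound to an amine nitrogen in a ring. No measured pair describes this kind of exchange, so the size and direction of the step cannot be read from the numbers shown. Compound 3 is expected to stay weak, because compound 2 gives "not active" (no number reported) and the shared part that changes is small. For compound 3 the estimate in this assay is 10000 nM, with a range from 1000 nM to 50000 nM.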

Compound 3, half-maximal effective concentration: 109 nM
Compound 3: middle estimate off by 92-fold (1.96 log units), on the high side; the whole stated range lies above it.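

In this assay, moving to (oxan-3-yl)methyl in place of (2,6-difluorophenyl)carbonyl gives a 4.0-fold higher number from compound 1 to compound 3 (0.61 log units; beyond the scatter), so a carbonyl-linked aromatic group on this ring nitrogen is not needed for a measurable effect, although compound 1 remains the better of the two. On the same saturated chain carbon, oxan-3-yl in place of phenyl separates compound 3, which has a number, from compound 2, which has none, so the size of that exchange cannot be read. No measured information explains this difference.

Going by these compounds, whether a cyclohexylmethyl group, with a carbon in place of the ring oxygen, would behave like (oxan-3-yl)methyl stays open. So does the result for (oxan-4-yl)methyl, which would show whether the place of that oxygen in the ring matters.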